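Aryl ether ring changes and stability of the shared core

A few compounds are considered here, and "the series" means these few. Any claim that something is new, unique, unknown or untested is made for them only; others in the source may bear on it.

Compound 1 `CCS(=O)(=O)Nc1ccc(Oc2ccc(F)cc2)c(-c2cn(C)c(=O)c3cncn23)c1` stands highest of the two compounds with a number in an ADME assay on microsomes from liver (Homo sapiens) for metabolic stability, with a stated time of 40 min, tested at 10 uM (a lower number here means that less of the compound is left, a higher number that more of the compound is left), where compound 1 gives 95.2%. Among the compounds with values here, compound 2 `CCS(=O)(=O)Nc1ccc(Oc2cc(C)ccc2F)c(-c2cn(C)c(=O)c3cncn23)c1` gives 14.1% in this assay, and the one measured step, a number 81.1 percentage points lower from compound 1 to compound 2 (beyond the scatter), shows that a change on the same aryl ether ring can move this assay far. Compound 3 `CCS(=O)(=O)Nc1ccc(Oc2ccc(-c3c(C)noc3C)cc2)c(-c2cn(C)c(=O)c3cncn23)c1` carries 3,5-dimethyl-1,2-oxazol-4-yl in place of fluoro on an aromatic carbon. Within the data shown here, no measured step covers this exact change, but the size of the step to compound 2 suggests a drop beyond the scatter, a number 45.2 percentage points lower from compound 1 to compound 3 (beyond the scatter), is the expected outcome. Compound 3 is estimated at 50%, within 15% to 90%.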

Compound 3, percent of the compound remaining: 54.3%
Compound 3: the middle estimate sits 4.3 percentage points below what was measured, and the stated range covers the measured number.
By their numbers in this assay, from the lowest: compound 2; then compound 3; then compound 1.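

In this assay, 3,5-dimethyl-1,2-oxazol-4-yl in place of fluoro on this aromatic carbon, para to a large group, gives a number 40.9 percentage points lower from compound 1 to compound 3 (beyond the scatter), so a change at this one position alone moves the number far. Even so, compound 3 still gives 54.3% with this much larger group in place. Nothing at hand explains the size of this step. As far as these compounds go, whether chloro, methoxy or a dimethylamino group on this carbon would stand nearer to compound 1 remains open. So does the share of the two methyl groups of the new ring in this step.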